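Moving the nitro group on a cyclohexanone bis-benzylidene scaffold

The source may hold more compounds than are shown below. What is called first, only, known or untested is meant among the compounds shown, and "the series" means these compounds.

Compound 1 `CN(C)c1ccc(/C=C2\CCC/C(=C\c3ccccc3[N+](=O)[O-])C2=O)cc1` and compound 3 `CN(C)c1ccc(/C=C2\CCC/C(=C\c3cccc([N+](=O)[O-])c3)C2=O)cc1` share a core, and compound 2 `COc1cc(/C=C2\CCC/C(=C\c3ccccc3[N+](=O)[O-])C2=O)cc(OC)c1OC` and compound 4 `COc1cc(/C=C2\CCC/C(=C\c3cccc([N+](=O)[O-])c3)C2=O)cc(OC)c1OC` share another; the difference between the two cores is not broken down here. In a functional assay on HSC-2 cells (Homo sapiens) for cytotoxicity, with a stated time of 24 h (a lower number here means that less compound is tolerated, a higher number that more compound is tolerated), compound 1 gives > 400000 nM, which is a limit of the assay rather than a number. Compound 3 gives 32000 nM in this assay, so the change 3-nitrophenyl in place of 2-nitrophenyl on a double-bonded chain carbon bound to a double-bonded ring carbon made a step of an at least 12-fold lower number from compound 1 to compound 3 (1.09 log units; beyond the scatter), a size that rests on (the limit of > 400000 nM in this assay, at which 1 of the 3 values shown sits). Compound 2 gives 5900 nM in this assay. Compound 4 carries the same change, (3-nitrophenyl in place of 2-nitrophenyl on a double-bonded chain carbon bound to a double-bonded ring carbon), on the core of compound 2. Compound 4 is therefore expected to give a lower number than compound 2, with an estimated step of a 3.0-fold lower number from compound 2 to compound 4 (0.47 log units; beyond the scatter), resting on compound 3 and its step of an at least 12-fold lower number from compound 1 to compound 3 (1.09 log units; beyond the scatter). Compound 4 is thus estimated at 2000 nM, between 500 nM and 8000 nM.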

Compound 4, half-maximal cytotoxic concentration: 73000 nM
Compound 4: middle estimate off by 37-fold (1.56 log units), on the low side; measured number outside the range, above it.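

In this assay, the same swap to 3-nitrophenyl gave a 12-fold higher number from compound 2 to compound 4 (1.09 log units; beyond the scatter), so the change did not carry over from one core to the other, neither in direction nor in size: the same change on two cores in this assay, an at least 12-fold lower number (1.09 log units; beyond the scatter) from compound 1 to compound 3 and a 12-fold higher number (1.09 log units; beyond the scatter) from compound 2 to compound 4, at least 150-fold (2.18 log units) apart, beyond the scatter of two such steps. The earlier step has no exact size, since it starts from a limit of the assay and not a number: the limit of > 400000 nM in this assay, at which 1 of the 4 values shown sits. The two pairs show that the outcome of this change differs with the core, but they do not show which part of the core matters, and they set no rule for the series.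

Going by these compounds, it remains open how the swap behaves on a core carrying another group, such as a carboxylic acid or a longer amine chain. On these data alone, whether such cores would follow compound 3 or compound 4 also stays unknown.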